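The compounds below may be only part of what the source reports. "The series", "measured", "known", "first", "only" and "open" are said of these compounds alone.

Measured compounds in the series:

Compound 1 `Cc1ccc(-c2cn(C/C=C3\OC(=O)C(OCc4ccccc4)=C3OCc3ccccc3)nn2)cc1`. In a functional assay on A549 cells (Homo sapiens) for antiproliferative activity, read by MTT assay, with a stated time of 72 h (a lower number here means a stronger inhibitor, a higher number a weaker inhibitor), compound 1 gives > 100000 nM, which is a limit of the assay and not a number.
Compound 2 `O=C1O/C(=C\Cn2cc(-c3cc(F)cc(F)c3)nn2)C(OCc2ccccc2)=C1OCc1ccccc1`. In this assay compound 2 gives > 100000 nM, again a limit of the assay.
Compound 3 `COc1ccc(-c2cn(C/C=C3\OC(=O)C(OCc4ccccc4)=C3OCc3ccccc3)nn2)cc1`. In this assay compound 3 gives > 100000 nM, also a limit of the assay.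

Compound 3 therefore stands at the limit, as do the two other measured compounds: the limit of > 100000 nM in this assay, at which 3 of the 3 values shown sit. The steps among the three are a step that the two limits leave unreadable from compound 1 to compound 2, a step that the two limits leave unreadable from compound 1 to compound 3 and a step that the two limits leave unreadable from compound 2 to compound 3; none of them can be read in size or direction, since both ends of each step sit at the limit.

Compound 4 `O=C1O/C(=C\Cn2cc(-c3cccc(O)c3)nn2)C(OCc2ccccc2)=C1OCc1ccccc1` differs from compound 3 by 3-hydroxyphenyl in place of 4-methoxyphenyl on an aromatic carbon. Going by the values given here, the steps that bear on this change are those that exchange the aryl group on the same aromatic carbon of the five-membered ring, namely a step that the two limits leave unreadable from compound 1 to compound 3 and a step that the two limits leave unreadable from compound 2 to compound 3, and both are unreadable. Among the compounds with values here, no size of step in this assay can be derived from them; the expectation is only that compound 4 stays where the measured compounds stand, with the expected step of a number no higher from compound 3 to compound 4 (the limit leaves the size open) amounting to nothing beyond the scatter.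

Compound 4 is accordingly estimated at 100000 nM, in the expected range 30000 nM to 300000 nM, most likely reported again as a limit.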

Compound 4, half-maximal inhibitory concentration: 23300 nM
The estimate for compound 4 lay 4.3-fold (0.63 log units) above the measured number; the measured number lies below the stated range.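

On the aromatic carbon of the five-membered ring, 3-hydroxyphenyl is the only aryl group shown that gives a number rather than a limit in this assay, with an at least 4.2-fold lower number from compound 3 to compound 4 (0.63 log units; beyond the scatter), an at least 4.2-fold lower number from compound 2 to compound 4 (0.63 log units; beyond the scatter) and an at least 4.2-fold lower number from compound 1 to compound 4 (0.63 log units; beyond the scatter). Each of these sizes is only a minimum, since the other end of each step is a limit of the assay, so the position is now shown to respond to a change of aryl group, though the full size of that response stays unknown. The steps among compound 1, compound 2 and compound 3 still cannot be read, and only compound 4 stands clear of the limit: the limit of > 100000 nM in this assay, at which 3 of the 4 values shown sit.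

Compound 3 and compound 4 differ both in the oxygen group (methoxy against hydroxy) and in where it sits on the phenyl ring, so a 4-hydroxyphenyl or a 3-methoxyphenyl group would be needed to separate the two. On these data alone, how an amine or a carboxylic acid on that phenyl ring would read in this assay also stays open.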